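Bromo removal in a phenolic triazole series

A few compounds are considered here, and "the series" means these few. Any claim that something is new, unique, unknown or untested is made for them only; others in the source may bear on it.

compound 1, `C=C1C[C@]23C[C@@]1(O)CC[C@H]2c1ccc(O)c(C)c1[C@@H]3Cn1cc(-c2ccccn2)nn1`, in a functional assay on MCF7 cells (Homo sapiens) for cytotoxicity, read by MTT assay, with a stated time of 4 days; on this read-out higher numbers stand for weaker inhibition and lower numbers for stronger inhibition: > 20000 nM, a limit of the assay
compound 2, `C=C1C[C@]23C[C@@]1(O)CC[C@H]2c1cc(Br)c(O)c(C)c1[C@@H]3Cn1cc(-c2ccc(F)cc2)nn1`, in this assay: 19200 nM

Among the compounds with values here, compound 2 holds the only number in this assay. Compound 1 sits at a limit of the assay, (the limit of > 20000 nM in this assay, at which 1 of the 2 values shown sits). Within the data shown here, no pair of measured compounds differs in a single place, so no measured step is available. Compound 3, `C=C1C[C@]23C[C@@]1(O)CC[C@H]2c1ccc(O)c(C)c1[C@@H]3Cn1cc(-c2ccc(F)cc2)nn1`, differs from compound 2 by hydrogen in place of bromo on an aromatic carbon. The step of a 1.3-fold higher number from compound 2 to compound 3 (0.11 log units; within the scatter) is expected to stay within the scatter, with a fair chance that only a limit is reported. For compound 3 the estimate is 25000 nM, ranging from 9000 nM to 70000 nM.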

Compound 3, half-maximal inhibitory concentration: > 20000 nM
Compound 3: no number, only a limit; the forecaster's own chance of this, stated with the estimate: 60%; the middle value is on the limit's open side.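

In this assay compound 3 gives > 20000 nM, a limit of the assay. Hydrogen in place of bromo ortho to the hydroxy group gives an at least 1.0-fold higher number from compound 2 to compound 3 (0.01 log units; that floor lies within the scatter), so this position shows no readable dependence on bromo, and the true size of the step remains unknown. With this result, the limit now holds most of the set: the limit of > 20000 nM in this assay, at which 2 of the 3 values shown sit.

The step between compound 1 and compound 3 cannot be read, since both values are limits. From the compounds shown here alone, whether an amine or a methoxy group at this position would give a number inside the assay's range stays open.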